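Replacing the amide group of compound 2

The source may hold more compounds than are shown below. What is called first, only, known or untested is meant among the compounds shown, and "the series" means these compounds.

In an ADME assay on HepG2 2.2.15 cells (Homo sapiens) for cytotoxicity, read by MTT assay, with stated times of 48 h and 9 days (on this read-out lower numbers stand for higher toxicity in this test and higher numbers for lower toxicity in this test), compound 1 (`O=C(/C=C/c1coc2cc(O)ccc2c1=O)NCc1ccccc1`) gives 436000 nM. Compound 2 (`COc1ccc2c(=O)c(/C=C/C(=O)Nc3ccccc3Cl)coc2c1`) gives 1010000 nM, the higher of the two numbers, and the gap lies beyond the usual scatter. Compound 3 (`COc1ccc2c(=O)c(/C=C/C(=O)NCc3ccccc3F)coc2c1`) carries 2-fluorobenzyl in place of 2-chlorophenyl on an amide-type nitrogen. Within the data shown here, no measured pair shows this change alone, and the only hint is that compound 1, also a benzyl amide, has the lower number. A small downward step within the scatter is expected, estimated as a 1.7-fold lower number from compound 2 to compound 3 (0.23 log units; within the scatter). The expected value for compound 3 is 600000 nM, with an estimated range from 220000 nM to 1500000 nM.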

Compound 3, half-maximal cytotoxic concentration: 146000 nM
The estimate for compound 3 lay 4.1-fold (0.61 log units) above the measured number, and the stated range ends above it.
By their numbers in this assay, from the lowest: compound 3; then compound 1; then compound 2.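

On the amide-type nitrogen, the group matters in this assay: putting 2-fluorobenzyl in place of 2-chlorophenyl gives a 6.9-fold lower number from compound 2 to compound 3 (0.84 log units; beyond the scatter), so the toxicity read-out responds to a change at this position. The change swaps the halogen and adds one carbon at the same time, so this single step cannot assign the shift to either one. No measurement here explains the step. Going by these compounds, it remains open how this position would respond to a simple alkyl chain, or to a group carrying an amine or a carboxylic acid.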